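Allyl Thioether Replaces Ester Chain on a Shared Core

A few compounds are considered here, and "the series" means these few. Any claim that something is new, unique, unknown or untested is made for them only; others in the source may bear on it.

Measured compounds:
compound 1, `C=CCSc1nncc2cnc(COC)n12`: 79000 nM
compound 2, `CCOC(=O)CSc1nncc2cnc(C)n12`: 52000 nM

The study concerns a functional assay for inhibition, with Homo sapiens as the target; a higher number here means a weaker inhibitor, a lower number a stronger inhibitor. For the measured compounds named here, only two compounds carry numbers so far. Compound 2 has the lower of the two, but the gap between compound 2 and compound 1 lies within the scatter, so nothing can be said about an order between them; both sit at weak inhibition.

Compound 3, `C=CCSc1nncc2cnc(C)n12`, has not yet been measured. Relative to compound 2 its structure differs in one place: vinyl in place of ethoxycarbonyl on a saturated chain carbon bound to a sulfur. The sulfur-linked chain of compound 3 is the same one that compound 1 carries, while the core substituent of compound 3 is the methyl of compound 2.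

Going by the values given here, with no step between measured compounds available, the expectation for this change rests only on the fact that compound 1 and compound 2, which differ at both places, give numbers within the scatter of each other. The step from compound 2 to compound 3 is therefore expected to be no larger than the scatter, a 1.2-fold higher number from compound 2 to compound 3 (0.08 log units; within the scatter), in neither direction. For compound 3 the estimate in this assay is 62000 nM, with a range from 25000 nM to 150000 nM.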

Compound 3, half-maximal inhibitory concentration: 61000 nM
Estimate against measurement, compound 3: 1.0-fold (0.01 log units) above; the measured number falls inside the stated range.
By their numbers in this assay, from the lowest: compounds 2, 3 and 1 (each within the scatter of the next).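

With compound 3 in hand, the two places that differ between compound 1 and compound 2 can be read one at a time in this assay, which the earlier pair, differing at both at once, did not allow. Vinyl in place of ethoxycarbonyl on a saturated chain carbon bound to a sulfur gives (a 1.2-fold higher number from compound 2 to compound 3 (0.07 log units; within the scatter)), and hydrogen in place of methoxy on a saturated chain carbon bound to an aromatic carbon gives (a 1.3-fold lower number from compound 1 to compound 3 (0.11 log units; within the scatter)), so neither single change moves the number beyond the scatter, even though the first removes a group of 5 heavy atoms with 2 hydrogen-bond acceptors. Nothing measured alongside these numbers offers an explanation for this result.

All three compounds stay at weak inhibition, so the compounds shown leave open whether any group on the saturated chain carbon bound to a sulfur, such as a carboxylic acid, an amine or a longer chain, would shift the number beyond the scatter. As far as these compounds go, whether an amine on the saturated chain carbon bound to an aromatic carbon would do so also remains open.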